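Two-Methyl Branching Added to a Tetrazole Chain

The source may report more compounds than this note shows. Statements on the series, on what has been measured and on what is new or still open speak of the compounds shown alone.

Of the compounds shown here, two with a shared core have been measured so far. Compound 1 `CCCc1c(COc2ccc(C(=O)CCC(=O)O)cc2)ccc(C(C)=O)c1O` carries a 2-carboxyethyl group on a carbonyl carbon, and in a functional assay on ileum (Cavia porcellus) with cysteinyl leukotriene receptor (Homo sapiens) as the target (on this read-out lower numbers stand for lower potency and higher numbers for higher potency (the scale is a negative logarithm)), compound 1 gives 6.75. Compound 2 `CCCc1c(COc2ccc(C(=O)C(C)Cc3nnn[nH]3)cc2)ccc(C(C)=O)c1O` replaces that group with 1-((1H-tetrazol-5-yl)methyl)ethyl, and in this assay compound 2 gives 7.18. Within the data shown here, that single change produced a number 0.43 log units higher from compound 1 to compound 2 (beyond the scatter), so compound 2 stands highest of the two numbers, with compound 1 as its only neighbour.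

Compound 3 `CCCc1c(COc2ccc(C(=O)CC(C)(C)Cc3nnn[nH]3)cc2)ccc(C(C)=O)c1O` is the next candidate. Its change from compound 2 is 2-((1H-tetrazol-5-yl)methyl)-2-methylpropyl in place of 1-((1H-tetrazol-5-yl)methyl)ethyl on a carbonyl carbon. Among the measured compounds shown here, the only measured step, from compound 1 to compound 2, swapped a carboxylic acid for a tetrazole; it does not address lengthening and branching of the carbon chain that holds the tetrazole, so it bears on the new step only weakly. With the acid-like tetrazole kept and only the chain altered, no step beyond the scatter is expected in this assay. Compound 3 is therefore estimated at 7.1, within 6.5 to 7.7, meaning an expected step of a number 0.08 log units lower from compound 2 to compound 3 (within the scatter).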

Compound 3, negative logarithm of the antagonist equilibrium constant: 7.86
Compound 3: middle estimate off by 0.76 log units, on the low side; measured number outside the range, above it.
By their numbers in this assay, from the lowest: compound 1; then compound 2; then compound 3.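

Replacing 1-((1H-tetrazol-5-yl)methyl)ethyl with 2-((1H-tetrazol-5-yl)methyl)-2-methylpropyl on this carbonyl carbon leaves the tetrazole ring in place and alters only the carbon chain that carries it, yet this assay shows a number 0.68 log units higher from compound 2 to compound 3 (beyond the scatter) in this comparison. The number at this position therefore depends on the shape of the chain as well as on the tetrazole at its end, which the earlier swap of acid for tetrazole could not show. Set against the carboxymethyl group of the first compound, the 1-((1H-tetrazol-5-yl)methyl)-1-methylethyl group gives a number 1.11 log units higher from compound 1 to compound 3 (beyond the scatter) and a large overall gain, placing compound 3 highest of the three, but nothing measured here explains the rise.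

Compound 3 differs from compound 2 in both the length of the chain and the placement and number of its methyl groups, so these compounds cannot separate the share of each. Going by these compounds, it remains open whether an unbranched chain of the same length would match compound 3, and whether a carboxylic acid in place of the tetrazole on the branched chain would do the same.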